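Swapping the aryl amide in a cyclohexane-diamide mGluR5 series

The compounds below may be only part of what the source reports. "The series", "measured", "known", "first", "only" and "open" are said of these compounds alone.

Compound 1 `CN(C)c1ccc(C(=O)N[C@H]2CCC[C@H](NC(=O)c3cccc(Cl)c3)C2)cc1` and compound 2 `O=C(N[C@H]1CCC[C@H](NC(=O)c2cccc(Cl)c2)C1)c1ccncc1` share a core carrying a 3-chlorobenzamide and a second aryl amide. In a functional assay on HEK293 cells for antagonist activity at metabotropic glutamate receptor 5 (Homo sapiens), read by FLIPR and calcium flux (on this read-out lower numbers stand for stronger inhibition and higher numbers for weaker inhibition), compound 1 gives 473 nM, and compound 2 gives 300 nM; the step of a 1.6-fold lower number from compound 1 to compound 2 (0.20 log units; within the scatter) is within the scatter, so the two stand level. Compound 3 `O=C(N[C@H]1CCC[C@H](NC(=O)c2cccc(Cl)c2)C1)c1ccc(F)cc1` differs from compound 2 by 4-fluorophenyl in place of pyridin-4-yl on a carbonyl carbon. For the measured compounds named here, only that one step bears on this change, and it showed no shift beyond the scatter, so compound 3 is expected to stay close to compound 2, with an expected step of a 1.2-fold higher number from compound 2 to compound 3 (0.07 log units; within the scatter). The estimate for compound 3 is 350 nM, between 120 nM and 1000 nM.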

Compound 3, half-maximal inhibitory concentration: 194 nM
Estimate against measurement, compound 3: 1.8-fold (0.26 log units) above; the range from low to high includes it.
By their numbers in this assay, from the lowest: compounds 3, 2 and 1 (each within the scatter of the next, the first and the last beyond it).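

The step of a 1.5-fold lower number from compound 2 to compound 3 (0.19 log units; within the scatter) leaves 4-fluorophenyl and pyridin-4-yl level on this carbonyl carbon, so the ring nitrogen is not needed to hold the number here. The step of a 2.4-fold lower number from compound 1 to compound 3 (0.39 log units; beyond the scatter) is the only one in the set that clears the scatter, though modestly, with fluoro in place of dimethylamino on an aromatic carbon. Nothing available explains this difference. Going by these compounds, whether an amine, a carboxylic acid or a longer chain at this place would move the number beyond the scatter stays open.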